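Two Inverted Stereocentres in a Cyclic Peroxide Acid

The source may report more compounds than this note shows. Statements on the series, on what has been measured and on what is new or still open speak of the compounds shown alone.

Compound 1 `COC(=O)[C@H](C)[C@H]1CC[C@@](C)(CCC2=C(C)CCCC2(C)C)OO1`: > 25000 nM
Compound 2 `C=C1CCCC(C)(C)C1CC[C@@]1(C)CC[C@H]([C@@H](C)C(=O)O)OO1`: > 12500 nM

In a functional assay on SK-MEL-28 cells (Homo sapiens) for inhibition (a higher number here means a weaker inhibitor of growth, a lower number a stronger inhibitor of growth), compound 1 gives only a limit, > 25000 nM, not a number. Compound 2 likewise gives only a limit, > 12500 nM. Both measured compounds thus sit at limits of this assay, so neither can be placed above or below the other. Compound 3 `C=C1CCCC(C)(C)C1CC[C@]1(C)CC[C@@H]([C@@H](C)C(=O)O)OO1` keeps every atom and bond of compound 2 and differs only in stereochemistry: the two compounds have the same atoms and bonds; at least one stereo element is drawn with a configuration in one of them and without one in the other: 2 of 4 stereo elements differ; a stereocentre at a saturated ring carbon is drawn S in compound 2 and R in compound 3; a stereocentre at a saturated ring carbon is drawn R in compound 2 and S in compound 3. Within the data shown here, no step between measured compounds exists, and both values are limits, so no change beyond the scatter is expected. The expected step is estimated as a step that the limit leaves unreadable from compound 2 to compound 3. Compound 3 is expected to give 20000 nM in this assay, within a range from 5000 nM to 60000 nM.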

Compound 3, concentration for 50% growth inhibition: > 10000 nM
Compound 3: a limit, no number (the forecaster's own chance of this, stated with the estimate: 70%); the middle value does not contradict the limit.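

Among these compounds, compound 2 and compound 3 both give only limits, not numbers, so no step between them can be read. As far as these compounds go, whether swapping the two ring stereocentres changes growth inhibition at all remains open.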